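Aromatic Ring Changes and Cytotoxicity in Three Analogues

The source may hold more compounds than are shown below. What is called first, only, known or untested is meant among the compounds shown, and "the series" means these compounds.

Measured compounds:
compound 1 `C[C@H]1CC[C@@H]2[C@@H](OC(=O)[C@]23CC(c2c(Cl)cccc2Cl)=NO3)[C@]2(C)C(=O)C=C[C@@]12O` with 38000 nM
compound 2 `C[C@H]1CC[C@@H]2[C@@H](OC(=O)[C@]23CC(c2ccc(Cl)cc2)=NO3)[C@]2(C)C(=O)C=C[C@@]12O` with 43000 nM
compound 3 `C[C@H]1CC[C@@H]2[C@@H](OC(=O)[C@]23CC(c2ccccc2)=NO3)[C@]2(C)C(=O)C=C[C@@]12O` with 39800 nM

In a functional assay on DU-145 cells (Homo sapiens) for cytotoxicity, read by sulforhodamine B assay, with a stated time of 48 h (on this read-out higher numbers stand for weaker inhibition and lower numbers for stronger inhibition), compound 1 gives 38000 nM and compound 2 gives 43000 nM, while compound 3 gives 39800 nM. Compound 3 therefore holds the second highest of the three numbers, with compound 1 nearest and compound 2 furthest, both differences within the scatter. The three measured steps all alter the aromatic ring attached to the carbon with a double bond to nitrogen: a 1.1-fold higher number from compound 1 to compound 2 (0.05 log units; within the scatter), a 1.0-fold higher number from compound 1 to compound 3 (0.02 log units; within the scatter) and a 1.1-fold lower number from compound 2 to compound 3 (0.03 log units; within the scatter). None of them leaves the scatter.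

Compound 4 `C[C@H]1CC[C@@H]2[C@@H](OC(=O)[C@]23CC(c2ccccc2[N+](=O)[O-])=NO3)[C@]2(C)C(=O)C=C[C@@]12O` differs from compound 3 by nitro in place of hydrogen on an aromatic carbon. This change again touches only the aromatic ring, the part of the molecule that the measured steps from compound 1, compound 2 and compound 3 show to be tolerant to substitution in this assay. Compound 4 is accordingly expected to show no step beyond the scatter, a 1.0-fold higher number from compound 3 to compound 4 (0.00 log units; within the scatter). The estimated value for compound 4 is 40000 nM, within the range 20000 nM to 80000 nM.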

Compound 4, half-maximal inhibitory concentration: 34000 nM
Compound 4: the middle estimate sits 1.2-fold (0.07 log units) above what was measured, and the stated range covers the measured number.
By their numbers in this assay, from the lowest: compounds 4, 1, 3 and 2 (each within the scatter of the next).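

In this assay the nitro group is the first group other than chloro shown on this aromatic ring, and it sits ortho to a large group, yet it gives a 1.2-fold lower number from compound 3 to compound 4 (0.07 log units; within the scatter). Set against the chlorinated analogues, 2-nitrophenyl gives a 1.3-fold lower number from compound 2 to compound 4 (0.10 log units; within the scatter) and a 1.1-fold lower number from compound 1 to compound 4 (0.05 log units; within the scatter), so phenyl, 4-chlorophenyl, 2,6-dichlorophenyl and 2-nitrophenyl all lie within the scatter of one another here. No measurement on hand speaks to what lies behind these small steps.

The compounds shown leave open whether an amine, a carboxylic acid or a longer chain on this ring would produce a step beyond the scatter. They also leave open whether nitro elsewhere on the ring would read the same, and whether a change to the shared core would matter more than any change to the ring.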